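A few compounds are considered here, and "the series" means these few. Any claim that something is new, unique, unknown or untested is made for them only; others in the source may bear on it.

In a functional assay on ECa-109 cells for inhibition, with ECa-109 cell line (Homo sapiens) as the target, read by MTT assay, with a stated time of 48 h (a lower number here means a stronger inhibitor, a higher number a weaker inhibitor), compound 1 `COc1cc(Nc2nc(Nc3ccc(Cl)cc3)nnc2Cl)cc(OC)c1OC`, which carries 4-chlorophenyl on a nitrogen, gives 32600 nM. Two relatives differ from it only in that group. Compound 2 `COc1cccc(Nc2nnc(Cl)c(Nc3cc(OC)c(OC)c(OC)c3)n2)c1`, with 3-methoxyphenyl in its place, gives 15900 nM, which is a 2.1-fold lower number from compound 1 to compound 2 (0.31 log units; beyond the scatter). Compound 3 `COc1cc(Nc2nc(Nc3ccc4c(ccn4C)c3)nnc2Cl)cc(OC)c1OC`, with 1-methyl-1H-indol-5-yl in its place, gives 42100 nM, which is a 1.3-fold higher number from compound 1 to compound 3 (0.11 log units; within the scatter). Compound 1 therefore stands level with compound 3 and apart from compound 2, and the widest gap among the three is a 2.6-fold higher number from compound 2 to compound 3 (0.42 log units; beyond the scatter).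

Compound 4 `COc1cc(Nc2nc(Nc3ccc(C(C)=O)cc3)nnc2Cl)cc(OC)c1OC` keeps the core of compound 1 and changes only the group on that phenyl ring: acetyl in place of chloro on an aromatic carbon. It is acetyl in place of chloro on an aromatic carbon, para to a large group. Among the measured compounds shown here, none of the measured compounds carries an acetyl, so the data do not test this group directly. The closest guide is that replacing the whole aryl group moved the number only modestly, by a 2.1-fold lower number from compound 1 to compound 2 (0.31 log units; beyond the scatter) at most from compound 1. A smaller substituent swap is thus expected to give no step beyond the scatter, with no firm direction. The estimated step is a 1.2-fold lower number from compound 1 to compound 4 (0.07 log units; within the scatter). For compound 4 the expected value is 28000 nM, with an estimated range from 11000 nM to 65000 nM.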

Compound 4, half-maximal inhibitory concentration: 36300 nM
Compound 4: middle estimate off by 1.3-fold (0.11 log units), on the low side, and the stated range covers the measured number.
By their numbers in this assay, from the lowest: compound 2; then compounds 1, 4 and 3 (each within the scatter of the next).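

In this assay, acetyl in place of chloro on an aromatic carbon, para to a large group, gives no step beyond the scatter (a 1.1-fold higher number from compound 1 to compound 4 (0.05 log units; within the scatter)), so at this place a larger group with a double bond outside the ring and a hydrogen-bond acceptor leaves the number where the chloro group had it. The 4-acetylphenyl group also stands level with 1-methyl-1H-indol-5-yl (a 1.2-fold lower number from compound 3 to compound 4 (0.06 log units; within the scatter)), while the gap to 3-methoxyphenyl lies beyond the scatter (a 2.3-fold higher number from compound 2 to compound 4 (0.36 log units; beyond the scatter)), which leaves compound 2 as the only one of the four set apart from the others. Nothing given here accounts for these numbers, and no cause can be assigned to them.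

The compounds shown leave open whether an amine or a carboxylic acid on this aromatic carbon, or a longer chain ending in a hydroxyl group, would move the number beyond the scatter. Also open, going by these compounds, is whether the lower number of compound 2 goes with the methoxy group itself or with where it sits on the ring.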